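The source may report more compounds than this note shows. Statements on the series, on what has been measured and on what is new or still open speak of the compounds shown alone.

Measured so far:
compound 3, `Cc1ccc(S(=O)(=O)n2cc(-c3cc(C(F)(F)F)cc(-c4cn(S(=O)(=O)c5ccc(C)cc5)c5cc(Br)ccc45)n3)c3ccc(Br)cc32)cc1`, 10%
compound 1, `COc1ccc2c(-c3cc(C(F)(F)F)c(C#N)c(-c4cn(S(=O)(=O)c5ccc(C)cc5)c5cc(OC)ccc45)n3)cn(S(=O)(=O)c3ccc(C)cc3)c2c1`, 9.1%
compound 2, `COc1ccc2c(c1)c(-c1cc(C(F)(F)F)cc(-c3cn(S(=O)(=O)c4ccc(C)cc4)c4ccc(OC)cc34)n1)cn2S(=O)(=O)c1ccc(C)cc1`, 7%

In a functional assay on P388 cells (Mus musculus) for inhibition, tested at 1 uM (a higher number here means a stronger effect of the compound at the concentration tested, a lower number a weaker effect), compound 3 gives the highest of the three numbers, yet its nearest neighbour compound 1 lies within the scatter of it, as does compound 2, so none of the three can be called stronger than another. Compound 1 and compound 2 both show small effects at this concentration.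

Compound 4, `Cc1ccc(S(=O)(=O)n2cc(-c3cc(C(F)(F)F)c(C#N)c(-c4cn(S(=O)(=O)c5ccc(C)cc5)c5cc(Br)ccc45)n3)c3ccc(Br)cc32)cc1`, differs from compound 3 by cyano in place of hydrogen on an aromatic carbon. Compound 1 carries a cyano group and compound 2 does not, and their numbers sit within the scatter of each other. The step of no change at the digits printed from compound 3 to compound 4 (within the scatter) is therefore expected to be small, with no direction beyond the scatter. For compound 4 the estimate is 10%, between 0% and 25%.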

Compound 4, a percentage reported as inhibition, at one concentration (the size of the read-out at that concentration, not a potency): 1.7%
Estimate against measurement, compound 4: 8.3 percentage points above, within the range that was stated.
By their numbers in this assay, from the lowest: compounds 4, 2, 1 and 3 (each within the scatter of the next).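

Among these compounds, the pair compound 3 and compound 4 gives the first reading of this position on its own: in this assay, cyano in place of hydrogen, ortho to a trifluoromethyl group, gives a number 8.3 percentage points lower from compound 3 to compound 4 (within the scatter). Cyano at this carbon therefore makes no readable difference, although both compounds start from small effects, which leaves little room to see a loss. Nothing shown explains the step.

On these data alone, whether an amine or a carboxylic acid on this carbon would move the number beyond the scatter remains open.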